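This account rests on a few compounds, and the source may have more. Where it says the series, first, only, none or still open, it means among the compounds named here.

Measured compounds in a functional assay on HCT-116 cells (Homo sapiens) for antiproliferative activity, read by MTT assay, with a stated time of 48 h; a lower number here means a stronger inhibitor, a higher number a weaker inhibitor:
compound 1 `CS(=O)(=O)c1ccc(Nc2nccc(Nc3nc4ccccc4s3)n2)cc1`, compound 1 gives 8370 nM
compound 2 `Cc1ccc2nc(Nc3ccnc(Nc4ccc(S(C)(=O)=O)cc4)n3)sc2c1`, compound 2 gives 1750 nM
compound 3 `CS(=O)(=O)c1ccc(Nc2nccc(Nc3nc4ccc(Cl)cc4s3)n2)cc1`, compound 3 gives 1350 nM

Compound 3 has the lowest number of the three, but its separation from compound 2 is only a 1.3-fold lower number from compound 2 to compound 3 (0.11 log units; within the scatter), so the two cannot be ordered. Only compound 1 is clearly apart: a 6.2-fold lower number from compound 1 to compound 3 (0.79 log units; beyond the scatter) and a 4.8-fold lower number from compound 1 to compound 2 (0.68 log units; beyond the scatter) are both beyond the scatter, so a substituent at this position of the shared core improves the result whether it is methyl or chloro.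

Compound 4 `COc1ccc2nc(Nc3ccnc(Nc4ccc(S(C)(=O)=O)cc4)n3)sc2c1` is not yet measured. It differs from compound 3 as follows: methoxy in place of chloro on an aromatic carbon. Among the compounds with values here, the steps that bear on this are the two substitutions at the same carbon, each of which lowered the number against compound 1 by a comparable amount, and the exchange between them, which did not move the number beyond the scatter. Within the data shown here, no measured step tells how methoxy itself compares with chloro or methyl here. The expectation is therefore a step from compound 3 to compound 4 of no more than the scatter, a 1.4-fold higher number from compound 3 to compound 4 (0.15 log units; within the scatter), with some leaning toward a higher number given that compound 3 stands lowest. Compound 4 is estimated at 1900 nM, with a range from 700 nM to 5000 nM in this assay.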

Compound 4, half-maximal inhibitory concentration: 2270 nM
Compound 4: middle estimate off by 1.2-fold (0.08 log units), on the low side, within the range that was stated.
By their numbers in this assay, from the lowest: compounds 3, 2 and 4 (each within the scatter of the next); then compound 1.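

Working notes on the position. In this assay methoxy also stands clear of hydrogen at this carbon, with a 3.7-fold lower number from compound 1 to compound 4 (0.57 log units; beyond the scatter), so all three groups shown here, including one that brings a hydrogen-bond acceptor, separate from the unsubstituted compound 1, and none of the four compounds goes against this. The exchange with the other two groups gives a 1.7-fold higher number from compound 3 to compound 4 (0.23 log units; within the scatter) and a 1.3-fold higher number from compound 2 to compound 4 (0.11 log units; within the scatter), both within the scatter, so compound 2, compound 3 and compound 4 cannot be ordered and the identity of the group among methyl, chloro and methoxy makes no readable difference at this carbon. No supporting data are available to account for the shared separation from compound 1.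

Still open, as far as these compounds go, is whether this level holds for groups of another kind at the same carbon, such as an amine, a carboxylic acid or a longer alkoxy chain, or whether any of these would move the number beyond the scatter in either direction. Also open, from the compounds shown here alone, is whether the same groups on other carbons of this six-membered ring would behave as they do here.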